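Series notes: amide substituent change at compound 3 to compound 4

The compounds below may be only part of what the source reports. "The series", "measured", "known", "first", "only" and "open" are said of these compounds alone.

The series shares one core, read in a functional assay on NCI-H1975 cells (Homo sapiens) for antiproliferative activity, read by MTT assay, with a stated time of 72 h; a higher number here means a weaker inhibitor, a lower number a stronger inhibitor. Compound 1 `C=C(Cl)C(=O)Nc1cc(Nc2nccc(-c3cn(C)c4ccccc34)n2)c(OC)cc1N(C)CCN(C)C` gives 1290 nM. Compound 2 `CC/C=C\C(=O)Nc1cc(Nc2ncc(C#N)c(-c3cn(C)c4ccccc34)n2)c(OC)cc1N(C)CCN(C)C` gives 1150 nM. Among the measured compounds shown here, compound 3 `C=C(Cl)C(=O)Nc1cc(Nc2nc(C)cc(-c3cn(C)c4ccccc34)n2)c(OC)cc1N(C)CCN(C)C` gives 2230 nM, the highest of the three numbers, though its distance to compound 1 and to compound 2 lies within the scatter; the one measured step, a 1.7-fold higher number from compound 1 to compound 3 (0.24 log units; within the scatter), is also within the scatter.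

Compound 4 `CCC/C=C\C(=O)Nc1cc(Nc2nc(C)cc(-c3cn(C)c4ccccc34)n2)c(OC)cc1N(C)CCN(C)C` differs from compound 3 in one place: pent-1-en-1-yl in place of 1-chloroethenyl on a carbonyl carbon. For the measured compounds named here, no measured step isolates this change. Going by the values given here, compound 1 and compound 2 carry different groups on the carbonyl carbon but also differ elsewhere, so their pair gives no clean step; their two values are within the scatter of each other. Among the compounds with values here, on that basis no step beyond the scatter is expected for a 1.1-fold higher number from compound 3 to compound 4 (0.05 log units; within the scatter), with the uncertainty wide because no direct precedent exists. Compound 4 is estimated at 2500 nM, in the range 1000 nM to 6500 nM.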

Compound 4, half-maximal inhibitory concentration: 254 nM
Estimate against measurement, compound 4: 9.8-fold (0.99 log units) above; measured number below the stated range.
By their numbers in this assay, from the lowest: compound 4; then compounds 2, 1 and 3 (each within the scatter of the next).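

In this assay, the group on the carbonyl carbon is the one place among the shown changes where a single replacement moves the number beyond the scatter: pent-1-en-1-yl in place of 1-chloroethenyl gives an 8.8-fold lower number from compound 3 to compound 4 (0.94 log units; beyond the scatter) on the shared core. Among the compounds shown here, the only earlier step, methyl in place of hydrogen on an aromatic carbon, stayed within the scatter, so this amide substituent is a position to which the assay responds, though the reading rests on one pair. No available data bear on what lies behind this step.

Which part of the change carries the step, the loss of chlorine or the longer chain, remains open; a plain ethenyl group or a longer alkenyl chain on the same carbonyl carbon would separate the two. Also open, from the compounds shown here alone, is whether pent-1-en-1-yl gives a similar step on the core of compound 1, which carries hydrogen where compound 3 carries methyl.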